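Swapping Thiophene Attachment Point on a Triaryl Pyridine Core

This account rests on a few compounds, and the source may have more. Where it says the series, first, only, none or still open, it means among the compounds named here.

Measured compounds:
- compound 1 `Clc1ccc(-c2cc(-c3cccs3)nc(-c3ccccc3Cl)c2)o1`: 17200 nM
- compound 2 `Clc1ccc(-c2cc(-c3ccc(Cl)o3)cc(-c3ccsc3)n2)cc1`: 18700 nM
- compound 3 `Cc1ccc(-c2cc(-c3ccc(Cl)o3)cc(-c3ccsc3)n2)o1`: 23300 nM

In a functional assay on K562 cells (Homo sapiens) for cytotoxicity, in the presence of a further agent that is not named here (a higher number here means a weaker inhibitor, a lower number a stronger inhibitor), compound 2 stands second highest of the three numbers, with compound 1 nearest and compound 3 furthest, and both of those gaps sit within the scatter. Among the compounds with values here, the only step measured from compound 2 is a 1.2-fold higher number from compound 2 to compound 3 (0.10 log units; within the scatter). Compound 4 `Clc1ccc(-c2cc(-c3ccc(Cl)o3)cc(-c3cccs3)n2)cc1` differs from compound 2 by thiophen-2-yl in place of thiophen-3-yl on an aromatic carbon. Within the data shown here, no measured step covers this change; compound 1 carries the thiophen-2-yl group but differs in further places, so its value shows nothing about this step alone. The account therefore expects no step beyond the scatter in this assay, that is a 1.0-fold lower number from compound 2 to compound 4 (0.02 log units; within the scatter). Compound 4 is estimated at 18000 nM, in the range 9000 nM to 36000 nM.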

Compound 4, half-maximal inhibitory concentration: 20900 nM
The estimate for compound 4 lay 1.2-fold (0.06 log units) below the measured number; measured number inside the range.
By their numbers in this assay, from the lowest: compounds 1, 2, 4 and 3 (each within the scatter of the next).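

In this assay, thiophen-2-yl and thiophen-3-yl on the aromatic carbon next to the ring nitrogen are not told apart, the step being a 1.1-fold higher number from compound 2 to compound 4 (0.05 log units; within the scatter) for this swap. With thiophen-2-yl held in place, 4-chlorophenyl in place of 2-chlorophenyl gives a 1.2-fold higher number from compound 1 to compound 4 (0.08 log units; within the scatter) and so likewise leaves the number within the scatter. No evidence accompanies these results that could account for them. Still open, from the compounds shown here alone, is whether an amine or a carboxylic acid at this position would shift the number. Also open, going by these compounds, is whether the thiophene swap would behave alike alongside the 5-methylfuran-2-yl group of compound 3.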